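Swapping a Hydroxybutyl Chain for a Methoxyphenyl Ring

This account rests on a few compounds, and the source may have more. Where it says the series, first, only, none or still open, it means among the compounds named here.

This study works on a shared core, seen in compound 1 `OCCCCCNCc1nc2c(OCC3CCCCC3)cccc2[nH]1`. The read-out is an assay on cells for inhibition of interleukin-5 receptor subunit alpha (Mus musculus), read by WST assay, with a stated time of 48 h, tested at 30 uM, in the presence of a further agent that is not named here; on this read-out lower numbers stand for less inhibition and higher numbers for more inhibition at the one concentration tested (going by the name of the read-out). In this assay, among the measured compounds shown here, compound 1 gives 23.7%, the lowest of the two numbers measured so far. For the measured compounds named here, the only other measured compound, compound 2 `OCCC(NCc1nc2c(OCC3CCCCC3)cccc2[nH]1)c1ccccc1`, gives 64.7% in this assay, a gap that lies beyond the usual scatter, so the two compounds truly differ here.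

The unmeasured compound 3 `COc1ccc(CNCc2nc3c(OCC4CCCCC4)cccc3[nH]2)cc1` differs from compound 1 in one place: 4-methoxyphenyl in place of 4-hydroxybutyl on a saturated chain carbon bound to an amine nitrogen. Going by the values given here, no measured pair shows exactly this kind of change, so the expectation rests only on the two values shown. Since compound 2, which reaches 64.7%, shows that this core can give far stronger inhibition than compound 1, a step upward from compound 1 to compound 3 is expected, beyond the scatter, as a number 26.3 percentage points higher from compound 1 to compound 3 (beyond the scatter). For compound 3 the estimated inhibition in this assay is 50%, most likely between 25% and 75%.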

Compound 3, a percentage reported as inhibition, at one concentration (the size of the read-out at that concentration, not a potency): 43.3%
Estimate against measurement, compound 3: 6.7 percentage points above, and the stated range covers the measured number.
By their numbers in this assay, from the lowest: compound 1; then compound 3; then compound 2.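

In this assay, among the compounds shown here, replacing 4-hydroxybutyl with 4-methoxyphenyl on a saturated chain carbon bound to an amine nitrogen gives a number 19.6 percentage points higher from compound 1 to compound 3 (beyond the scatter) and is the first single-place change read at this position. It shows that the ring-free chain is not needed for inhibition at the one concentration tested, since a six-membered aromatic ring of carbon only can take its place and the number still rises. Several things change together in this one step, as the group grows from 5 to 8 heavy atoms, gains a ring and goes from 1 hydrogen-bond donor to 0, and nothing measured here explains the rise or ties it to any one of these changes.

On these data alone, what remains open is which of these changes carries the step: a 4-hydroxyphenyl group would keep the ring together with the donor, while a 4-methoxybutyl chain would keep the open chain without it. The compounds shown also leave open how this position responds to quite different groups, such as a carboxylic acid or an amine at the end of the chain.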